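The compounds below may be only part of what the source reports. "The series", "measured", "known", "first", "only" and "open" are said of these compounds alone.

Measured so far in a functional assay on A549 cells (Homo sapiens) for cytotoxicity, read by MTT assay, with a stated time of 72 h; on this read-out lower numbers stand for an effect already at smaller amounts and higher numbers for an effect only at larger amounts of compound:

- compound 1, `CCS[C@@H]1[C@H](SCC)[C@@H](Cn2cc(-c3ccc(OC)cc3)nn2)O[C@H]1n1ccc(=O)[nH]c1=O`: 16800 nM
- compound 2, `CCS[C@@H]1[C@H](SCC)[C@@H](Cn2cc(-c3ccccc3)nn2)O[C@H]1n1cc(C)c(=O)[nH]c1=O`: 31700 nM

Compound 2 stands at the higher of the two numbers in this assay. Its nearest neighbour is compound 1, whose value lies within the scatter of the value of compound 2, so the two numbers cannot be ordered.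

Compound 3, `CCS[C@@H]1[C@H](SCC)[C@@H](Cn2cc(-c3ccc(OC)cc3)nn2)O[C@H]1n1cc(C)c(=O)[nH]c1=O`, has not yet been measured in this assay. It differs from compound 2 in one place: methoxy in place of hydrogen on an aromatic carbon. Going by the values given here, no step between two measured compounds carries this change, so its size is not known from the series. Compound 1 carries the same methoxy group on the same ring and gives a number close to that of compound 2, but compound 1 also differs from compound 3 elsewhere, so its value is a loose anchor only.

The expectation is a step from compound 2 to compound 3 of a 1.4-fold lower number from compound 2 to compound 3 (0.16 log units; within the scatter), not beyond the scatter, in either direction. The estimate for compound 3 in this assay is 22000 nM, with a range from 8000 nM to 60000 nM.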

Compound 3, half-maximal effective concentration: 38800 nM
The estimate for compound 3 lay 1.8-fold (0.25 log units) below the measured number; the range from low to high includes it.
By their numbers in this assay, from the lowest: compounds 1, 2 and 3 (each within the scatter of the next, the first and the last beyond it).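

In this assay the change from phenyl to 4-methoxyphenyl now has a size: it reads as a 1.2-fold higher number from compound 2 to compound 3 (0.09 log units; within the scatter) and so stays within the scatter, which means that methoxy in place of hydrogen at this place gives no readable change on this core. Going by these compounds alone, the only step beyond the scatter lies at the other place, where a methyl group enters, with a 2.3-fold higher number from compound 1 to compound 3 (0.36 log units; beyond the scatter) and so a modest effect resting on this single pair. No measurement at hand accounts for either step.

From the compounds shown here alone, it remains open whether a different group at the methoxy place, such as an amine or a carboxylic acid, would move the number beyond the scatter. Also open, going by these compounds, is whether the methyl step holds with phenyl in place of 4-methoxyphenyl, and what a longer chain on that aromatic carbon would do.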